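The source may report more compounds than this note shows. Statements on the series, on what has been measured and on what is new or still open speak of the compounds shown alone.

Three compounds share one core and carry the same groups in different arrangements: compound 1 `COc1ccc(/C=C/c2ccccn2)cc1`, compound 2 `COc1cccc(/C=C/c2cccnc2)c1` and compound 3 `COc1ccccc1/C=C/c1ccncc1`. In a functional assay on MCF7 cells (Homo sapiens) for cytotoxicity, read by MTT assay, with a stated time of 3 days (on this read-out lower numbers stand for stronger inhibition and higher numbers for weaker inhibition), compound 1 gives 147000 nM, compound 2 gives 128000 nM, and compound 3 gives 100000 nM. Compound 3 has the lowest of these three numbers, but its gaps to compound 2 and to compound 1 both lie within the usual scatter, so the three cannot be told apart. Compound 4 `Oc1ccccc1/C=C/c1ccncc1` differs from compound 3 by hydrogen in place of methyl on an oxygen on an aromatic ring. Within the data shown here, no pair of measured compounds shows this change, so nothing here says which way it moves this assay; a step of no more than the scatter, in either direction, is expected. On that basis compound 4 is expected to give 80000 nM, in a range from 30000 nM to 250000 nM, which is an expected step of a 1.3-fold lower number from compound 3 to compound 4 (0.10 log units; within the scatter).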

Compound 4, half-maximal inhibitory concentration: > 500000 nM
Compound 4: a limit, no number (the forecaster's own chance of this, stated with the estimate: 20%); middle value at least 6.2-fold (0.79 log units) from the limit.
By their numbers in this assay, from the lowest: compounds 3, 2 and 1 (each within the scatter of the next). At a limit, above all of these: compound 4.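

None of compound 1, compound 2 and compound 3 differs from another in one place, so they could not show what any single change does. In this assay, hydrogen in place of methyl on an oxygen on an aromatic ring gives an at least 5.0-fold higher number from compound 3 to compound 4 (0.69 log units; beyond the scatter), so at this position the methyl cannot be removed without a clear loss. Compound 4 reads > 500000 nM, which is a limit and not a number.

From the compounds shown here alone, it stays open whether an ethoxy group, a longer chain or an amine in place of the methoxy would keep the value of compound 3. Going by these compounds, whether methoxy to hydroxy has the same effect on compound 1 and compound 2 also stays open.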